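Swapping (2-hydroxyethyl)amino for 3-carboxyazetidin-1-yl

This account rests on a few compounds, and the source may have more. Where it says the series, first, only, none or still open, it means among the compounds named here.

Within the data shown here, in a functional assay on HepG2 cells (Homo sapiens) for antiproliferative activity, read by CCK-8 assay, with a stated time of 48 h (a lower number here means a stronger inhibitor, a higher number a weaker inhibitor), compound 3 (`COc1ccc(/C=C\c2cc(OC)c(OC)c(OC)c2)cc1OCc1ccc(CNCCO)cc1`) gives 5900 nM as the only actual number so far. Compound 1 (`COc1ccc(/C=C\c2cc(OC)c(OC)c(OC)c2)cc1OCc1ccc(CN2CCCC[C@H]2C(=O)O)cc1`) gives > 10000 nM as a limit of the assay rather than a number. Compound 2 (`COc1ccc(/C=C\c2cc(OC)c(OC)c(OC)c2)cc1OCc1ccc(CN[C@H](C(=O)O)[C@H](C)O)cc1`) gives > 10000 nM as a limit too.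

Compound 4 (`COc1ccc(/C=C\c2cc(OC)c(OC)c(OC)c2)cc1OCc1ccc(CN2CC(C(=O)O)C2)cc1`) carries the change 3-carboxyazetidin-1-yl in place of (2-hydroxyethyl)amino on a saturated chain carbon bound to an aromatic carbon and so puts 3-carboxyazetidin-1-yl in place of (2-hydroxyethyl)amino on a saturated chain carbon bound to an aromatic carbon. Among the measured compounds shown here, two measured steps bear on it, an at least 1.6-fold lower number from compound 1 to compound 3 (0.22 log units; that floor lies within the scatter) and an at least 1.6-fold lower number from compound 2 to compound 3 (0.22 log units; that floor lies within the scatter) and each of them leaves a carboxy-bearing group for (2-hydroxyethyl)amino. For the measured compounds named here, with these two steps as the only guides, the return of a carboxy group in compound 4 is expected to push the number in this assay upward, toward the limit of > 10000 nM in this assay, at which 2 of the 3 values shown sit, and not away from it. The estimated shift is a 2.2-fold higher number from compound 3 to compound 4 (0.34 log units; beyond the scatter) and the assay may well report only a limit. The expected value for compound 4 is 13000 nM (estimated range 6000 nM to 30000 nM).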

Compound 4, half-maximal inhibitory concentration: > 10000 nM
Compound 4: only a limit was reported; the forecaster's own chance of this, stated with the estimate: 70%; the middle value is on the limit's open side.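

In this assay compound 4 gives > 10000 nM, which is a limit of the assay and not a number. What can be read is an at least 1.6-fold higher number from compound 3 to compound 4 (0.22 log units; that floor lies within the scatter), so this limit does not establish a real difference from compound 3, and the steps among compounds 1, 2 and 4 cannot be read. The change shows that a carboxy-bearing group held in a four-membered ring, on the saturated chain carbon bound to an aromatic carbon, also gives no number, like the open-chain and six-membered carboxy-bearing groups of compounds 2 and 1: the limit of > 10000 nM in this assay, at which 3 of the 4 values shown sit.

The compounds shown leave open how far past the limit compounds 1, 2 and 4 lie. They also leave open whether a plain azetidin-1-yl group, a methyl ester of the carboxylic acid, or a longer hydroxyalkyl chain on the amine would give a number in this assay.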